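Compound 1 to compound 4: a step from a limit

This account rests on a few compounds, and the source may have more. Where it says the series, first, only, none or still open, it means among the compounds named here.

compound 1 `O=C(Nc1ccnnc1)c1cc(C(F)(F)F)ccc1OCc1ccccc1`: < 1000 nM (a limit)
compound 2 `O=C(Nc1cccc(F)c1)c1cc(C(F)(F)F)ccc1OCc1ccc(F)cc1`: < 1000 nM (a limit)
compound 3 `O=C(Nc1cccnc1)c1cc(C(F)(F)F)ccc1OCc1ccccc1`: < 1000 nM (a limit)

In a physicochemical assay for solubility, measured as kinetic solubility (a lower number here means a less soluble compound, a higher number a more soluble compound), compound 1 gives < 1000 nM, which is a limit and not a number.

Compound 4 `C[C@@H]1CN(c2ccc(OCc3ccccc3)c(C(=O)Nc3ccnnc3)c2)C[C@H](C)O1` keeps the core of compound 1 but carries 2,6-dimethylmorpholin-4-yl in place of trifluoromethyl on an aromatic carbon.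

Within the data shown here, the one measured step here is a step that the two limits leave unreadable from compound 1 to compound 3. Among the measured compounds shown here, that step concerns the group on the amide nitrogen, so it offers no size to carry over, and no measured step touches the trifluoromethyl group. What the data do offer is the limit of < 1000 nM in this assay, at which 3 of the 3 values shown sit, so compound 4 is expected to land around that same limit, with no firm direction and no step beyond the scatter expected.

The estimated step is a step that the limit leaves unreadable from compound 1 to compound 4.

For compound 4 the estimated value is 800 nM, with an expected range from 250 nM to 2500 nM.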

Compound 4, solubility: 29000 nM
The estimate for compound 4 lay 36-fold (1.56 log units) below the measured number, outside the stated range (above it).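

In this assay compound 1 gives < 1000 nM, which is a limit and not a number. Placing 2,6-dimethylmorpholin-4-yl in place of trifluoromethyl, on the aromatic carbon para to a benzyloxy group, gives an at least 29-fold higher number from compound 1 to compound 4 (1.46 log units; beyond the scatter), so this position can carry a change that moves the read-out well beyond the usual scatter. Compound 4 is the only compound shown with a readable number, while the changes on the amide nitrogen among the earlier compounds give no readable step: the limit of < 1000 nM in this assay, at which 3 of the 4 values shown sit.

This single swap cannot separate the contributions of the ring oxygen, the two methyl groups and the two defined stereocentres. Also open, on these data alone, is whether plain morpholin-4-yl or an open-chain amine such as dimethylamino at this carbon would give a similar number, and whether the step carries over to the pyridin-3-yl amide of compound 3.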